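Amide Variation at the Carbonyl: Compound 2 to Compound 3

A few compounds are considered here, and "the series" means these few. Any claim that something is new, unique, unknown or untested is made for them only; others in the source may bear on it.

Compound 1, `CN(C)CCC(=O)Nc1cccc(-c2nc3ccccc3s2)c1`: in an ADME assay on HEK293 cells (Homo sapiens) for inhibition, with a stated time of 72 h (on this read-out lower numbers stand for an effect already at smaller amounts and higher numbers for an effect only at larger amounts of compound), compound 1 gives > 25000 nM, a limit of the assay.
Compound 2, `O=C(CCl)Nc1cccc(-c2nc3ccccc3s2)c1`: in this assay compound 2 gives 10000 nM.

Compound 2 holds the only number shown in this assay. The value of compound 1 is a limit only, (the limit of > 25000 nM in this assay, at which 1 of the 2 values shown sits). Within the data shown here, the single measured step, an at least 2.5-fold lower number from compound 1 to compound 2 (0.39 log units; beyond the scatter), exchanged the substituent on the saturated chain carbon bound to the carbonyl and moved the read-out at least modestly downward.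

Compound 3, `O=C(Nc1cccc(-c2nc3ccccc3s2)c1)c1ccc(Cl)nc1Cl`, changes the same side of the amide more deeply: 2,6-dichloropyridin-3-yl in place of chloromethyl on a carbonyl carbon. Among the measured compounds shown here, no measured step swaps the chloromethyl group for an aromatic ring, so the earlier step bears on this one only in showing that the group on the carbonyl carbon shifts the read-out; it sets no direction for an aryl replacement. The expected step is a 1.3-fold lower number from compound 2 to compound 3 (0.10 log units; within the scatter), with a fair chance that only a limit is returned. Compound 3 is therefore estimated at 8000 nM, within a range from 2000 nM to 30000 nM.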

Compound 3, half-maximal effective concentration: > 25000 nM
Compound 3: no number, only a limit; the forecaster's own chance of this, stated with the estimate: 30%; middle value at least 3.1-fold (0.49 log units) away from the limit.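

In this assay, the group on the carbonyl carbon now has an aromatic replacement, and 2,6-dichloropyridin-3-yl in place of chloromethyl gives an at least 2.5-fold higher number from compound 2 to compound 3 (0.39 log units; beyond the scatter). The value of compound 3, > 25000 nM, is a limit of the assay and not a number, so this step fixes a direction and only a minimum size. The step between compound 1 and compound 3 cannot be read, and among the groups shown on this carbonyl carbon, chloromethyl remains the only one with a number: the limit of > 25000 nM in this assay, at which 2 of the 3 values shown sit.

The compounds shown leave open whether the higher read-out goes with the aromatic ring as such or with its two chlorine atoms, a question on which an unsubstituted phenyl group on the carbonyl carbon would bear. Also open, going by these compounds, is whether the chlorine of the chloromethyl group matters for the number of compound 2, which a plain methyl group in its place would help to settle.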